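Hydrazone aryl swap on the shared core: pyrrolyl to dimethylaminophenyl

This account rests on a few compounds, and the source may have more. Where it says the series, first, only, none or still open, it means among the compounds named here.

Measured so far in an assay on CHO-K1 cells for displacement of a labelled ligand from adenosine receptor A1 (Homo sapiens), read by scintillation counting, with a stated time of 60 min; on this read-out higher numbers stand for weaker inhibition and lower numbers for stronger inhibition:
- compound 2 `Nc1nc(N/N=C/c2ccc[nH]2)nc2c1ncn2[C@@H]1O[C@H](CO)[C@@H](O)[C@H]1O`: 8 nM
- compound 1 `Nc1nc(N/N=C/c2ccc(-c3ccc(Br)cc3)o2)nc2c1ncn2[C@@H]1O[C@H](CO)[C@@H](O)[C@H]1O`: 4.5 nM
- compound 3 `CCCOc1ccc(/C=N/Nc2nc(N)c3ncn([C@@H]4O[C@H](CO)[C@@H](O)[C@H]4O)c3n2)cc1`: > 10000 nM, a limit of this assay, not a number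

Compound 2 holds the higher of the two numbers in this assay; its nearest neighbour is compound 1, and the gap between compound 2 and compound 1 lies within the scatter, so no order between them can be read. Compound 3 sits at the limit, as noted in the limit of > 10000 nM in this assay, at which 1 of the 3 values shown sits.

The step to compound 4 `CN(C)c1ccc(/C=N/Nc2nc(N)c3ncn([C@@H]4O[C@H](CO)[C@@H](O)[C@H]4O)c3n2)cc1` changes the ring attached to the hydrazone carbon: 4-(dimethylamino)phenyl in place of 1H-pyrrol-2-yl on a carbon with a double bond to nitrogen

For the measured compounds named here, one measured step bears on this. Replacing 1H-pyrrol-2-yl with 4-propoxyphenyl on the same carbon gave an at least 1200-fold higher number from compound 2 to compound 3 (3.09 log units; beyond the scatter). Compound 4 carries 4-(dimethylamino)phenyl in that position, again a substituted phenyl in place of the five-membered ring, as in compound 3. By that step, a large increase in the number is expected for compound 4, and the expected change is a 1000-fold higher number from compound 2 to compound 4 (3.00 log units; beyond the scatter). Compound 4 is estimated at 8000 nM, with a range from 1500 nM to 40000 nM, and a reported limit rather than a number is a real possibility because compound 3 already sits at > 10000 nM.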

Compound 4, inhibition constant: > 10000 nM
Compound 4: a limit, no number (the forecaster's own chance of this, stated with the estimate: 50%); middle value at least 1.2-fold (0.09 log units) from the limit.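

In this assay, a second substituted phenyl on the carbon with a double bond to nitrogen gives the same outcome as the first, with an at least 1200-fold higher number from compound 2 to compound 4 (3.09 log units; beyond the scatter). The large step therefore no longer rests on 4-propoxyphenyl alone, and it holds for two different groups on the phenyl ring, with compound 3 and compound 4 both reported only as a limit of the assay, not as a number: the limit of > 10000 nM in this assay, at which 2 of the 4 values shown sit. Both ends of the step from propoxy to dimethylamino are limits, so that step cannot be read and no order between these two compounds can be given.

The change from 1H-pyrrol-2-yl to 4-(dimethylamino)phenyl alters several things at once, including ring size, the substituent and the loss of the hydrogen-bond donor, so the compounds shown do not assign the large step to any one of them. An unsubstituted phenyl would separate the ring from its substituent, and a pyrrole with a methyl on its nitrogen would separate the five-membered ring from its hydrogen-bond donor.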